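This account rests on a few compounds, and the source may have more. Where it says the series, first, only, none or still open, it means among the compounds named here.

The series shares the core shown by compound 1 `COc1c(/C=C2/C(=O)Nc3ccccc32)c2ccccc2n1-c1ccccc1`. In a functional assay on cells (Cancer cell lines, Homo sapiens) for cytotoxicity, with a stated time of 48 h (on this read-out lower numbers stand for stronger inhibition of growth and higher numbers for weaker inhibition of growth), compound 1 gives 3470 nM. Going by the values given here, compound 2 `COc1c(/C=C2/C(=O)Nc3ccc(Cl)cc32)c2ccccc2n1-c1ccccc1` carries chloro on an aromatic carbon of the fused core; in this assay compound 2 gives 24000 nM, the higher of the two numbers so far, with compound 1 as its only neighbour. Among the compounds with values here, the one measured step, a 6.9-fold higher number from compound 1 to compound 2 (0.84 log units; beyond the scatter), is the sole guide to what substitution at this carbon does.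

Compound 3 `COc1ccc2c(c1)/C(=C\c1c(OC)n(-c3ccccc3)c3ccccc13)C(=O)N2` differs from compound 2 by methoxy in place of chloro on an aromatic carbon. Within the data shown here, no measured step swaps one substituent for another at this position; only hydrogen and chloro have been compared there, and that comparison moved the number well beyond the scatter. A methoxy at the same carbon is taken as another substituted case, expected to fall between the hydrogen and chloro results. For compound 3 in this assay a step of a 2.0-fold lower number from compound 2 to compound 3 (0.30 log units; within the scatter) is therefore expected. The estimate for compound 3 in this assay is 12000 nM, with a range from 4000 nM to 40000 nM.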

Compound 3, concentration for total growth inhibition: 13200 nM
Beside the measured number, compound 3's estimate is 1.1-fold (0.04 log units) below it; low and high end bracket the measured number.
By their numbers in this assay, from the lowest: compound 1; then compounds 3 and 2 (each within the scatter of the next).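

In this assay, going by these compounds alone, methoxy in place of chloro gives a 1.8-fold lower number from compound 2 to compound 3 (0.26 log units; within the scatter), so the two substituted compounds cannot be told apart at this aromatic carbon, something the single comparison of hydrogen with chloro could not show. Methoxy in place of hydrogen gives a 3.8-fold higher number from compound 1 to compound 3 (0.58 log units; beyond the scatter), so a second substituent now goes the same way as chloro, and among the three compounds shown, none goes against the pattern that hydrogen at this carbon gives the lowest number, with both substituted compounds lying beyond the scatter of compound 1. Nothing further on hand bears on this result.

Still open, going by these compounds, is whether an amine, a carboxylic acid or a longer chain such as butoxy at this carbon would stay with chloro and methoxy or come back towards compound 1. Also open is whether the same substituents on other carbons of this six-membered aromatic ring would raise the number as they do here, since all the substituted compounds shown carry their group at this one carbon.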